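Removing a chloro from the dichlorophenyl arm of compound 3

The source may hold more compounds than are shown below. What is called first, only, known or untested is meant among the compounds shown, and "the series" means these compounds.

Compound 3 `C=C(C(=O)c1ccc(OC)cc1)C(OC(=O)c1ccccc1)c1ccc(Cl)cc1Cl` stands at the top of the numbers seen so far: in a functional assay on A549 cells (Homo sapiens) for inhibition, read by XTT assay, with a stated time of 48 h (on this read-out higher numbers stand for weaker inhibition and lower numbers for stronger inhibition), compound 3 gives 79200 nM, whereas compound 1 `COc1ccc(C(=O)/C(=C/C2CCCCC2)COC(=O)c2ccccc2)cc1` gives 36000 nM and compound 2 `C=C(C(=O)c1ccc(OC)cc1)C(OC(C)=O)c1ccc(Cl)cc1Cl` gives 17600 nM. Among the measured compounds shown here, the one single-point step measured, a 4.5-fold higher number from compound 2 to compound 3 (0.65 log units; beyond the scatter), swapped the acyl group, not the aryl ring. For the measured compounds named here, compound 4 `C=C(C(=O)c1ccc(OC)cc1)C(OC(=O)c1ccccc1)c1ccccc1Cl` differs from compound 3 by hydrogen in place of chloro on an aromatic carbon; no measured step bears on this change, so the expectation rests on compound 3 alone. With nothing to point either way, the step of a 1.2-fold lower number from compound 3 to compound 4 (0.09 log units; within the scatter) is expected to stay within the scatter. Compound 4 is therefore estimated at 65000 nM, with a range from 25000 nM to 170000 nM.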

Compound 4, half-maximal inhibitory concentration: 30500 nM
Compound 4: middle estimate off by 2.1-fold (0.33 log units), on the high side; the range from low to high includes it.
By their numbers in this assay, from the lowest: compounds 2, 4 and 1 (each within the scatter of the next, the first and the last beyond it); then compound 3.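

Going from the 2,4-dichlorophenyl to the 2-chlorophenyl arm gives a 2.6-fold lower number from compound 3 to compound 4 (0.41 log units; beyond the scatter) in this assay so the aryl ring, and not only the acyl group, shifts this read-out. At this place, para to the large group, the chloro is not needed for the stronger inhibition, as the number falls once hydrogen replaces it. Nothing measured here gives a reason for this step.

Going by these compounds, whether a fluoro or an amine at this place would lower the number further stays open. So does whether the same loss of chloro would lower the number with the acetyl group of compound 2 in place of the benzoyl group.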